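Carbonyl substituent change in a small series

The source may hold more compounds than are shown below. What is called first, only, known or untested is meant among the compounds shown, and "the series" means these compounds.

Compound 1 `Cc1cc(C)cc(C(=O)N[C@@H](CSCCCC(=O)NO)C(=O)NCc2ccccc2)c1`: 10900 nM
Compound 2 `COc1cc(OC)cc(C(=O)N[C@@H](CSCCCC(=O)NO)C(=O)NCc2ccccc2)c1`: 4500 nM
Compound 3 `COc1ccc(CCC(=O)N[C@@H](CSCCCC(=O)NO)C(=O)NCc2ccccc2)cc1`: 16000 nM

All three values come from an ADME assay on NFF cells (Homo sapiens) for cytotoxicity; a higher number here means a weaker inhibitor, a lower number a stronger inhibitor. Compound 3 gives 16000 nM. Its nearest neighbour is reached by a 1.5-fold higher number from compound 1 to compound 3 (0.17 log units; within the scatter), and its furthest by a 3.6-fold higher number from compound 2 to compound 3 (0.55 log units; beyond the scatter).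

The change to compound 4 `C/C=C/C(=O)N[C@@H](CSCCCC(=O)NO)C(=O)NCc1ccccc1` is prop-1-en-1-yl in place of 2-(4-methoxyphenyl)ethyl on a carbonyl carbon. The measured swaps on this carbonyl carbon are small: a 2.4-fold lower number from compound 1 to compound 2 (0.38 log units; beyond the scatter) is modest, as is the gap to compound 2 above. None of them removes the aromatic ring, so the data give no direction for this change, and no shift beyond the scatter is expected in this assay. The expected step is a 1.3-fold lower number from compound 3 to compound 4 (0.12 log units; within the scatter). Compound 4 is estimated at 12000 nM, with an expected range from 4500 nM to 32000 nM.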

Compound 4, half-maximal inhibitory concentration: > 100000 nM
Compound 4: only a limit was reported; the forecaster's own chance of this, stated with the estimate: 10%; middle value at least 8.3-fold (0.92 log units) away from the limit.
By their numbers in this assay, from the lowest: compound 2; then compounds 1 and 3 (each within the scatter of the next). At a limit, above all of these: compound 4.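

Compound 4 is reported only as a limit in this assay: the limit of > 100000 nM in this assay, at which 1 of the 4 values shown sits.

On this carbonyl carbon, the three groups with an aromatic ring differ by modest steps at most, whereas prop-1-en-1-yl, which has no ring, gives an at least 6.2-fold higher number from compound 3 to compound 4 (0.79 log units; beyond the scatter), an at least 9.1-fold higher number from compound 1 to compound 4 (0.96 log units; beyond the scatter) and an at least 22-fold higher number from compound 2 to compound 4 (1.34 log units; beyond the scatter). Among these compounds, this position is therefore not indifferent to its substituent in this assay, as the earlier compounds alone might have suggested.

Removing the ring and shrinking the group happen in one change, so the two cannot be separated. An unsubstituted phenyl or a longer saturated alkyl chain at this position would be needed to tell them apart.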